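The compounds below may be only part of what the source reports. "The series", "measured", "known", "first", "only" and "open" are said of these compounds alone.

Compound 3 `COc1ccc(-c2cccc(C(=O)N(C)Cc3ccccn3)c2)cc1S(=O)(=O)Nc1cccc(NCCNC(=O)c2cccc(C)c2)c1` is the starting point of this step. In a functional assay on CHO-RD-HGA16 cells for agonist activity at Orexin/Hypocretin receptor type 1 (Homo sapiens), read by fluorescence and calcium flux, with a stated time of 30 min (a higher number here means that more compound is needed for the effect, a lower number that less compound is needed), compound 3 gives 235 nM, the lowest of the two numbers measured among these compounds. Its nearest neighbour is compound 1 `COc1ccc(-c2cccc(C(=O)N(C)CCN(C)C)c2)cc1S(=O)(=O)Nc1cccc(NCCNC(=O)c2cccc(C)c2)c1`, which in this assay gives 638 nM; the only difference between the two is the group on the amide-type nitrogen, and that change reads a 2.7-fold lower number from compound 1 to compound 3 (0.43 log units; beyond the scatter). Compound 2 `COc1ccc(-c2cccc(C(=O)NCCN(C)C)c2)cc1S(=O)(=O)Nc1cccc(NCCNC(=O)c2cccc(C)c2)c1` in this assay gives only a limit, > 10000 nM. That limit is the limit of > 10000 nM in this assay, at which 1 of the 3 values shown sits.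

Compound 4 `COc1ccc(-c2cccc(C(=O)NCc3ccccn3)c2)cc1S(=O)(=O)Nc1cccc(NCCNC(=O)c2cccc(C)c2)c1` differs from compound 3 in one place: hydrogen in place of methyl on an amide-type nitrogen. The same exchange has been measured once before, going from compound 1 to compound 2, where it gave an at least 15-fold higher number from compound 1 to compound 2 (1.19 log units; beyond the scatter). The step from compound 2 to compound 3 combines that exchange with the change of the side group and gave an at least 42-fold lower number from compound 2 to compound 3 (1.62 log units; beyond the scatter), which is consistent with the methyl on the amide-type nitrogen mattering a great deal. A large rise in the number is therefore expected for compound 4, with a real chance that only a limit is reported. Compound 4 is expected to give about 5000 nM, with a plausible range from 1500 nM to 20000 nM, which corresponds to an expected 21-fold higher number from compound 3 to compound 4 (1.33 log units; beyond the scatter).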

Compound 4, half-maximal effective concentration: > 10000 nM
Compound 4 was reported as a limit (the forecaster's own chance of this, stated with the estimate: 45%); at least 2.0-fold (0.30 log units) between middle value and limit.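

In this assay, hydrogen in place of methyl on the amide-type nitrogen gives an at least 42-fold higher number from compound 3 to compound 4 (1.62 log units; beyond the scatter), so the large loss seen earlier with the (dimethylamino)methyl side group also appears with the pyridin-2-yl side group. Compound 4 gives only a limit, and it is the second compound in this set to do so: the limit of > 10000 nM in this assay, at which 2 of the 4 values shown sit. Compared with compound 1, replacing the whole amine part gives an at least 15-fold higher number from compound 1 to compound 4 (1.19 log units; beyond the scatter), while the step between compound 2 and compound 4 cannot be read, and the two pairs that show the hydrogen-for-methyl change can be compared only loosely: the same change on two cores in this assay, an at least 15-fold higher number (1.19 log units; beyond the scatter) from compound 1 to compound 2 and an at least 42-fold higher number (1.62 log units; beyond the scatter) from compound 3 to compound 4; the limit leaves it open whether they differ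

From the compounds shown here alone, with both compounds lacking the methyl reported as limits, it remains open whether the pyridin-2-yl group still makes any difference to the number once the methyl has gone. Going by these compounds, it is also open whether methyl itself is needed at this nitrogen or whether another carbon group, such as ethyl or cyclopropyl, would hold the number near that of compound 3.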